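The source may hold more compounds than are shown below. What is called first, only, known or untested is meant among the compounds shown, and "the series" means these compounds.

Working notes on the acid dissociation series.

Three compounds are measured in a physicochemical assay for acid dissociation. Compound 1 `CCCCCCS(=O)(=O)c1ccc(O)c(C(=O)Nc2ccc(Br)cc2)c1` gives 5.2. Compound 2 `CCCCCCCCCCCCS(=O)(=O)c1ccc(O)c(C(=O)Nc2ccc(C(F)(F)F)cc2)c1` gives 6.2. Compound 3 `CCCCCCS(=O)(=O)c1ccc(O)c(C(=O)Nc2ccc(C(F)(F)F)cc2)c1` gives 6.2. Compound 2 and compound 3 stand level at the digits shown and together give the highest of the three numbers; compound 1 stands apart from both.

Two measured steps are of use. Between compound 3 and compound 1 the change is bromo in place of trifluoromethyl on an aromatic carbon, and in this assay it gives a number 1.00 log units lower from compound 3 to compound 1 (beyond the scatter). Between compound 3 and compound 2 the cores differ by hexyl in place of hydrogen on a saturated chain carbon, six bonds along the chain from a sulfonyl sulfur, and in this assay this gives no change at the digits printed from compound 2 to compound 3 (within the scatter), so the hexyl chain length leaves the read-out untouched here.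

Compound 4 `CCCCCCCCCCCCS(=O)(=O)c1ccc(O)c(C(=O)Nc2ccc(Br)cc2)c1` is not yet measured. It differs from compound 2 by bromo in place of trifluoromethyl on an aromatic carbon. The description of where the change sits is identical, word for word, to that for the step from compound 3 to compound 1, so it is the same change, now on the longer-chain core. Among the compounds with values here, since the two cores themselves show no difference in this assay, the measured step is the only guide. The expected step is a number 1.00 log units lower from compound 2 to compound 4 (beyond the scatter), resting on the step from compound 3 to compound 1, a number 1.00 log units lower from compound 3 to compound 1 (beyond the scatter), on the other core. Compound 4 is therefore expected to give 5.2 in this assay, with a range from 4.8 to 5.6.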

Compound 4, acid dissociation constant: 5.2
Compound 4: middle estimate and measured number agree at the digits printed; the range from low to high includes it.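

In this assay the replacement of trifluoromethyl by bromo gives a number 1.00 log units lower from compound 2 to compound 4 (beyond the scatter) on the longer-chain core, and the printed size matches a number 1.00 log units lower from compound 3 to compound 1 (beyond the scatter) on the shorter-chain core, so this change carries from one core to the other across the four compounds shown. The chain step reads the same way with either aromatic group: no change at the digits printed from compound 1 to compound 4 (within the scatter) in the bromo pair sits alongside no change at the digits printed from compound 2 to compound 3 (within the scatter) in the trifluoromethyl pair, and no chain effect appears in this read-out for either pair. This is still one change on two cores that differ only in chain length, so it does not show that the step would hold on a core altered elsewhere, and nothing available here explains the size of the step or its constancy.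

What the compounds shown leave open is whether a chloro or a nitrile in place of bromo, on the same aromatic carbon, would fit the same pattern on both cores. Also open, going by these compounds, is whether the absence of a chain step in this assay would survive a chain ending in a carboxylic acid or an amine, or one longer than that of compound 2.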